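A few compounds are considered here, and "the series" means these few. Any claim that something is new, unique, unknown or untested is made for them only; others in the source may bear on it.

Working notes on the urea series sharing the core of compound 1 `Cc1ccc(NC(=O)Nc2cccc(CNc3nccnc3Cl)c2)cc1Cl`. Among the compounds with values here, in a functional assay on HepG2 cells (Homo sapiens) for antiproliferative activity, read by MTT assay, with a stated time of 48 h (on this read-out lower numbers stand for stronger inhibition and higher numbers for weaker inhibition), compound 1 gives 11300 nM, the second highest of the three numbers so far. Compound 2 `O=C(Nc1cccc(CNc2nccnc2Cl)c1)NC1CCCC1` gives 18400 nM and compound 3 `O=C(Nc1cccc(CNc2nccnc2Cl)c1)Nc1ccc(Cl)c(Cl)c1` gives 6170 nM. The measured steps are small: a 1.6-fold higher number from compound 1 to compound 2 (0.21 log units; within the scatter), a 1.8-fold lower number from compound 1 to compound 3 (0.26 log units; within the scatter) and a 3.0-fold lower number from compound 2 to compound 3 (0.47 log units; beyond the scatter); only the last reaches beyond the scatter.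

The next compound is compound 4 `COc1ccc(NC(=O)Nc2cccc(CNc3nccnc3Cl)c2)cc1`, which differs from compound 1 by 4-methoxyphenyl in place of 3-chloro-4-methylphenyl on an amide-type nitrogen. Within the data shown here, no measured step exchanges a methoxy group; the closest comparisons are the exchange of substituents on the same aryl ring a 1.8-fold lower number from compound 1 to compound 3 (0.26 log units; within the scatter) and the exchange of the whole group on the amide-type nitrogen a 1.6-fold higher number from compound 1 to compound 2 (0.21 log units; within the scatter), both within the scatter. Across the three compounds the whole spread on this assay is modest, so nothing here points to a large move in either direction for compound 4. The expectation is a step of a 1.2-fold higher number from compound 1 to compound 4 (0.09 log units; within the scatter), which would keep compound 4 within the scatter of compound 1. The estimate for compound 4 in this assay is 14000 nM, with a range from 6000 nM to 35000 nM.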

Compound 4, half-maximal inhibitory concentration: 12000 nM
For compound 4 the middle estimate is 1.2-fold (0.07 log units) above the measured one; measured number inside the range.
By their numbers in this assay, from the lowest: compounds 3, 1, 4 and 2 (each within the scatter of the next, the first and the last beyond it).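

In this assay, 4-methoxyphenyl in place of 3-chloro-4-methylphenyl on the amide-type nitrogen gives a 1.1-fold higher number from compound 1 to compound 4 (0.03 log units; within the scatter), so an exchange that removes the chlorine and brings in a hydrogen-bond acceptor produces no readable change at this position. Compound 4 also lies within the scatter of both other compounds, with a 1.9-fold higher number from compound 3 to compound 4 (0.29 log units; within the scatter) and a 1.5-fold lower number from compound 2 to compound 4 (0.19 log units; within the scatter), even though those two are separated by a 3.0-fold lower number from compound 2 to compound 3 (0.47 log units; beyond the scatter), so it adds a third group on this nitrogen that cannot be told apart from either of them and leaves that single step as the only readable difference in the series. Nothing available offers an explanation for these small steps.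

Still open, from the compounds shown here alone, is whether an amine or a carboxylic acid on the aryl ring, or a longer chain in place of cyclopentyl on the amide-type nitrogen, would move the number beyond the scatter of compound 1. The compounds shown also leave open what an exchange of the chlorine on the shared core would do, since every change so far sits on the same nitrogen.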